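This account rests on a few compounds, and the source may have more. Where it says the series, first, only, none or still open, it means among the compounds named here.

Measured in a functional assay on SW480 cells (Homo sapiens) for cytotoxicity, read by MTT assay, with a stated time of 48 h; on this read-out higher numbers stand for weaker inhibition and lower numbers for stronger inhibition:
- compound 1 `COc1cc([C@@H]2C[C@@]2(CO)C(=O)Nc2ccccc2)cc(OC)c1OC`: 76800 nM
- compound 2 `COc1cc([C@@H]2C[C@]2(CO)C(=O)Nc2ccccc2Cl)cc(OC)c1OC`: 13200 nM
- compound 3 `COc1cc([C@@H]2C[C@@]2(CO)C(=O)NCc2ccc(C)cc2)cc(OC)c1OC`: 76300 nM

Compound 3 stands at 76300 nM. This is within the scatter of compound 1, and both lie well above compound 2 at 13200 nM.

The next compound is compound 4 `COc1cc([C@@H]2C[C@@]2(CO)C(=O)Nc2ccccc2Cl)cc(OC)c1OC`, which carries 2-chlorophenyl in place of 4-methylbenzyl on an amide-type nitrogen. Among the compounds with values here, only one measured step changes this same place, a 1.0-fold lower number from compound 1 to compound 3 (0.00 log units; within the scatter), and it stays within the scatter. Exchanging phenyl for 4-methylbenzyl there therefore left the number unmoved, so losing 4-methylbenzyl alone gives no reason to expect a shift.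

The entering group is also found in compound 2, at 13200 nM. However, compound 2 is not the same structure as compound 4, and no measured step links the two, so it offers only a loose guide. The data contain no direct measure of what 2-chlorophenyl does in the setting of compound 3.

A moderate move toward a lower number in this assay therefore seems more likely than none, though it may not clear the scatter by much. The expected size of this move is a 2.0-fold lower number from compound 3 to compound 4 (0.30 log units; within the scatter). The estimate for compound 4 is 38000 nM, with an expected range from 13000 nM to 90000 nM.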

Compound 4, half-maximal inhibitory concentration: 10700 nM
Estimate against measurement, compound 4: 3.6-fold (0.55 log units) above; the measured number lies below the stated range.
By their numbers in this assay, from the lowest: compounds 4 and 2 (each within the scatter of the next); then compounds 3 and 1 (each within the scatter of the next).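

Within the data shown here, until this result, the group on the amide-type nitrogen had seemed to make no difference in this assay, but 2-chlorophenyl in place of 4-methylbenzyl gives a 7.1-fold lower number from compound 3 to compound 4 (0.85 log units; beyond the scatter), so this place does respond to change. The smaller change of chloro in place of hydrogen on an aromatic carbon gives a step of similar size, a 7.2-fold lower number from compound 1 to compound 4 (0.86 log units; beyond the scatter), showing that this single exchange on the phenyl amide is enough to pass beyond the scatter. The drawn configuration at the saturated ring carbon, by contrast, leaves the two chlorinated compounds within the scatter, with a 1.2-fold lower number from compound 2 to compound 4 (0.09 log units; within the scatter), and this pair isolates that one stereocentre: the fact that compounds 2 and 4 differ only in the configuration as drawn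

The compounds shown leave open whether fluoro, bromo, methoxy or an amine on the same phenyl would give a step like that of chloro, and whether the chloro would give the same step at another ring carbon. They also leave open whether the drawn configuration would matter any more for the unchlorinated phenyl amide of compound 1 than it does for the chlorinated pair.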